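This account rests on a few compounds, and the source may have more. Where it says the series, first, only, none or still open, it means among the compounds named here.

Measured so far:
- compound 1 `O=C(O)CCC(Cc1cccc(OCc2ccc3ccccc3n2)c1)c1ccccc1`: 56 nM
- compound 2 `c1ccc(C(CCc2nnn[nH]2)Cc2cccc(OCc3ccc4ccccc4n3)c2)cc1`: 24 nM

Both compounds were tested in a functional assay (lung) for inhibition, with Cavia porcellus as the target; a lower number here means a stronger inhibitor, a higher number a weaker inhibitor. Compound 2, at 24 nM, has the lower of the two numbers, so it is the stronger inhibitor of this pair. Within the data shown here, the one measured step is a 2.3-fold lower number from compound 1 to compound 2 (0.37 log units; beyond the scatter). It comes from putting 1H-tetrazol-5-yl in place of carboxy at the end of the chain.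

Compound 3 `CCCC(CCc1nnn[nH]1)Cc1cccc(OCc2ccc3ccccc3n2)c1` keeps that end group and changes a different part of the molecule: propyl in place of phenyl on a saturated chain carbon bound to two saturated chain carbons. The new group is propyl in place of phenyl, on a saturated chain carbon bound to two saturated chain carbons. Among the measured compounds shown here, no measured pair tests this change, so the data cannot fix its direction or size. The step of a 2.3-fold lower number from compound 1 to compound 2 (0.37 log units; beyond the scatter) offers only a rough sense of scale, since it was made elsewhere in the molecule. Removing an aromatic ring is a larger structural change than that one, so a modest weakening seems the more likely outcome, though with wide uncertainty. The expected change is a 2.5-fold higher number from compound 2 to compound 3 (0.40 log units; beyond the scatter). For compound 3 the estimated value is 60 nM, with an expected range of 15 nM to 250 nM.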

Compound 3, half-maximal inhibitory concentration: 16 nM
Beside the measured number, compound 3's estimate is 3.8-fold (0.57 log units) above it; measured number inside the range.
By their numbers in this assay, from the lowest: compounds 3 and 2 (each within the scatter of the next); then compound 1.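

In this assay, replacing the phenyl ring with the open-chain propyl group gives a 1.5-fold lower number from compound 2 to compound 3 (0.18 log units; within the scatter), so this measurement cannot tell compound 2 and compound 3 apart. For this pair, on a saturated chain carbon bound to two saturated chain carbons, an aromatic ring is therefore not needed to keep the number in this range, and propyl, with 3 heavy atoms, does as well here as phenyl, with 6 heavy atoms. No other measurement is available that would explain this outcome.

The compounds shown leave open how much this position will accept, since a longer chain such as hexyl, a branched group such as isopropyl, or a saturated ring such as cyclohexyl could each take the place of propyl. They also leave open whether propyl would give a similar result with the carboxy end group of compound 1 in place of the 1H-tetrazol-5-yl group.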